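The source may hold more compounds than are shown below. What is called first, only, known or untested is meant among the compounds shown, and "the series" means these compounds.

Measured compounds:
compound 1, `O=C1/C(=C/c2cccc(Br)c2)Cc2ccccc21`, 173000 nM in a functional assay on MOLT-4 cells (Homo sapiens) for inhibition; on this read-out higher numbers stand for weaker inhibition and lower numbers for stronger inhibition
compound 2, `Cc1cccc(/C=C2\Cc3ccccc3C2=O)c1`, 80300 nM in this assay
compound 3, `O=C1/C(=C/c2ccc(Br)cc2)CCc2ccccc21`, a limit in this assay

Compound 1 and compound 2 share one core, and between them the change is methyl in place of bromo on an aromatic carbon. That change gave a 2.2-fold lower number from compound 1 to compound 2 (0.33 log units; beyond the scatter). Compound 3 sits on a different core; the difference between the two cores is not broken down here. For compound 3 the value in this assay is only a limit, > 500000 nM.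

Compound 4, `Cc1ccc(/C=C2\CCc3ccccc3C2=O)cc1`, has not yet been measured. It differs from compound 3 by methyl in place of bromo on an aromatic carbon. Among the compounds with values here, this is the same kind of change as the one from compound 1 to compound 2, but not the same: there the methyl stands meta to a large group, here it stands para to a large group. If the new pair follows the earlier one, the step from compound 3 to compound 4 is expected to be an at least 1.2-fold lower number from compound 3 to compound 4 (0.09 log units; that floor lies within the scatter), set beside a 2.2-fold lower number from compound 1 to compound 2 (0.33 log units; beyond the scatter). Because compound 3 gives only > 500000 nM, the starting point is itself uncertain, and a modest gain may still leave compound 4 at the limit. For compound 4 the expected value in this assay is 400000 nM, between 150000 nM and 1500000 nM.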

Compound 4, half-maximal inhibitory concentration: > 500000 nM
Compound 4: a limit, no number; the forecaster's own chance of this, stated with the estimate: 55%; middle value at least 1.2-fold (0.09 log units) from the limit.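

Compound 3 and compound 4 both sit at a limit, so the step between them cannot be read: the limit of > 500000 nM in this assay, at which 2 of the 4 values shown sit.

The compounds shown leave open whether methyl in place of bromo changes inhibition at all on the core of compound 3, and whether the change seen between compound 1 and compound 2 carries over to that core.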